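The compounds below may be only part of what the source reports. "The series", "measured", "known", "first", "only" and "open" are said of these compounds alone.

Measured so far:
- Compound 1 `O=C(/C=C/c1cccnc1)NCCCc1ccc(S(=O)(=O)Nc2ccccc2)cc1`: 4120 nM
- Compound 2 `Cc1ccccc1NS(=O)(=O)c1cccc(CCCCCCNC(=O)/C=C/c2cccnc2)c1`: 0.226 nM

In a functional assay on MCF7 cells (Homo sapiens) for inhibition, read by CCK-8 assay, with a stated time of 72 h (on this read-out lower numbers stand for stronger inhibition and higher numbers for weaker inhibition), compound 2 gives the lower of the two numbers, and the gap to compound 1, which gives the higher number, lies well beyond the scatter. No single-point step connects the two, since they differ in more than one place, so the pair shows only that a very wide range is possible among these compounds.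

Compound 3 `O=C(/C=C/c1cccnc1)NCCCCCCc1cccc(S(=O)(=O)Nc2ccc(F)cc2)c1` is not yet measured. It differs from compound 2 in one place: 4-fluorophenyl in place of 2-methylphenyl on a sulfonamide nitrogen. Nothing in the measured pair isolates this change, so the direction rests on judgement alone. Because compound 2 stands at 0.226 nM, an exceptionally low number, compound 3 is expected to come in somewhat higher, with a step of an 8.8-fold higher number from compound 2 to compound 3 (0.95 log units; beyond the scatter) that likely exceeds the scatter. The estimate for compound 3 is 2 nM, within a range of 0.2 nM to 40 nM.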

Compound 3, half-maximal inhibitory concentration: 0.91 nM
For compound 3 the middle estimate is 2.2-fold (0.34 log units) above the measured one; the measured number falls inside the stated range.
By their numbers in this assay, from the lowest: compound 2; then compound 3; then compound 1.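

In this assay, for the compounds shown here, the exchange of 2-methylphenyl for 4-fluorophenyl on the sulfonamide nitrogen gives the first step that can be read in one place: a 4.0-fold higher number from compound 2 to compound 3 (0.60 log units; beyond the scatter). The change therefore moves the number only modestly, and the sub-nanomolar range is not confined to the 2-methylphenyl group, as compound 3 still gives 0.91 nM. No accompanying measurement accounts for the size or direction of this step.

The compounds shown leave open whether the step follows the methyl group, the fluorine or the place each occupies on the ring, a question that 2-fluorophenyl and 4-methylphenyl partners could separate. They also leave open how an amine or a carboxylic acid on this aryl group would fare, and what a longer chain would do with the rest of the structure held fixed.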